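Cyclopropyl for methyl on the shared lactam core

A few compounds are considered here, and "the series" means these few. Any claim that something is new, unique, unknown or untested is made for them only; others in the source may bear on it.

Compound 1 `CC(=O)N[C@@H]1CCCc2c1cncc2N1C(=O)c2ccc(Cl)cc2[C@@H]1C1CC1` gives > 30000 nM in an ADME assay on cells for inhibition of cytochrome P450 11B1, mitochondrial (Homo sapiens), read by HTRF; on this read-out higher numbers stand for weaker inhibition and lower numbers for stronger inhibition; this value is a limit of the assay, not a number.
Compound 2 `CC(=O)N[C@@H]1CCCc2c1cncc2N1C(=O)c2ccc(Cl)cc2[C@@H]1C` gives 81 nM in this assay.
Compound 3 `CC1c2cc(Cl)ccc2C(=O)N1c1cccnc1` gives 1250 nM in this assay.

The step from compound 2 to compound 1 is cyclopropyl in place of methyl on a saturated ring carbon, and it gives an at least 370-fold higher number from compound 2 to compound 1 (2.56 log units; beyond the scatter), reaching (the limit of > 30000 nM in this assay, at which 1 of the 3 values shown sits). The difference between the cores of compound 2 and compound 3 is not broken down here. Compound 4 `O=C1c2ccc(Cl)cc2C(C2CC2)N1c1cccnc1` carries the same kind of change on the core of compound 3: cyclopropyl in place of methyl on a saturated ring carbon; the place differs only in that the neighbouring ring atom bears a pyridin-3-yl group rather than a large group. Because an at least 370-fold higher number from compound 2 to compound 1 (2.56 log units; beyond the scatter) was large, a step of similar size is expected from compound 3 to compound 4 in this assay, namely an 80-fold higher number from compound 3 to compound 4 (1.90 log units; beyond the scatter). Compound 4 is therefore estimated at 100000 nM, most likely reported only as a limit.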

Compound 4, half-maximal inhibitory concentration: 32500 nM
Compound 4: the middle estimate sits 3.1-fold (0.49 log units) above what was measured; the range from low to high includes it.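

In this assay, cyclopropyl in place of methyl carries over from one core to the other in direction, with a 26-fold higher number from compound 3 to compound 4 (1.41 log units; beyond the scatter), but not in size: the same change on two cores in this assay, an at least 370-fold higher number (2.56 log units; beyond the scatter) from compound 2 to compound 1 and a 26-fold higher number (1.41 log units; beyond the scatter) from compound 3 to compound 4, at least 14-fold (1.15 log units) apart, beyond the scatter of two such steps. The step to compound 1 ends at a limit of the assay, which gives only a lower bound on its size: the limit of > 30000 nM in this assay, at which 1 of the 4 values shown sits. Two cores do not show which part of them sets the gap between the steps, and no general rule for the series follows from them.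

The compounds shown leave open how an ethyl group, an isopropyl group or a primary amine on this saturated ring carbon would read on either core. They also leave open whether the gap between the cores would persist with those groups.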